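A few compounds are considered here, and "the series" means these few. Any claim that something is new, unique, unknown or untested is made for them only; others in the source may bear on it.

Measured compounds and their results in the growth assay:

Compound 1, `COc1ccc(-c2cc(/C=C/C(=O)c3ccc(N)cc3)[nH]n2)cc1`: 2010 nM
Compound 2, `COc1ccc(C(=O)/C=C/c2cc(-c3cc(OC)c(OC)c(OC)c3)n[nH]2)cc1OC`: 1660 nM
Compound 3, `COc1ccc(-c2cc(/C=C/C(=O)c3ccc(N)cc3)[nH]n2)cc1OC`: 1670 nM

All three were tested in a functional assay on ACHN cells (Homo sapiens) for inhibition, read by sulforhodamine B assay, with a stated time of 48 h; on this read-out higher numbers stand for weaker inhibition of growth and lower numbers for stronger inhibition of growth. Compound 1 and compound 3 share one core and differ in a single place: methoxy in place of hydrogen on an aromatic carbon. This change gave a 1.2-fold lower number from compound 1 to compound 3 (0.08 log units; within the scatter), so the two compounds cannot be told apart on this read-out. Compound 2 is built on a different core; how the core of compound 2 differs from that of compound 1 is not broken down here. Its number in this assay sits with those of compound 1 and compound 3, and none of the three can be called stronger or weaker than another.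

Compound 4, `COc1cc(C(=O)/C=C/c2cc(-c3cc(OC)c(OC)c(OC)c3)n[nH]2)cc(OC)c1OC`, has not yet been measured. It differs from compound 2 by methoxy in place of hydrogen on an aromatic carbon. For the measured compounds named here, this is the same kind of change as the one from compound 1 to compound 3, though the surroundings are not identical: in compound 4 the entering methoxy is also meta to a methoxy group, which was not the case in compound 3. Since the earlier step stayed within the scatter, the expectation is that the step from compound 2 to compound 4 in this assay will be small as well, about a 1.1-fold lower number from compound 2 to compound 4 (0.04 log units; within the scatter), because compound 2 gives 1660 nM and the comparable change left a 1.2-fold lower number from compound 1 to compound 3 (0.08 log units; within the scatter). Compound 4 is therefore expected to give about 1500 nM, most likely between 700 nM and 3500 nM.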

Compound 4, concentration for 50% growth inhibition: 1620 nM
Beside the measured number, compound 4's estimate is 1.1-fold (0.03 log units) below it; measured number inside the range.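

In this assay, putting methoxy in place of hydrogen on an aromatic carbon of the core of compound 2 gives a step that stays within the usual scatter (a 1.0-fold lower number from compound 2 to compound 4 (0.01 log units; within the scatter)). Set beside the earlier case, the two steps cannot be told apart: the same change on two cores in this assay, a 1.2-fold lower number (0.08 log units; within the scatter) from compound 1 to compound 3 and a 1.0-fold lower number (0.01 log units; within the scatter) from compound 2 to compound 4, 1.2-fold (0.07 log units) apart, within the scatter of two such steps. This shows that, on these two cores and in this one assay, the swap of hydrogen for methoxy left the two compounds of each pair indistinguishable, but it does not show that a real, measurable effect carries from one core to the other, since neither step rises above the scatter, and two such results say nothing about how the swap would behave on a third core.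

The compounds shown carry only hydrogen or methoxy at the place of this swap, so it remains open whether a hydroxy group, a fluorine atom, a carboxylic acid or a longer chain such as ethoxy would move the number beyond the scatter. From the compounds shown here alone, it also remains open whether the same pattern would appear in cells other than those of this assay.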